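Imidazolyl alkyne in place of methylpyridyl alkyne

The source may report more compounds than this note shows. Statements on the series, on what has been measured and on what is new or still open speak of the compounds shown alone.

Measured compounds:
compound 1 `O=C(O)COc1ccc(Cl)cc1C#Cc1ccncc1` gives 601 nM
compound 2 `Cc1ncccc1C#Cc1cc(Cl)ccc1OCC(=O)O` gives 143 nM
compound 3 `COCc1ccc(F)c(C#Cc2cc(Cl)ccc2OCC(=O)O)c1` gives 72 nM

All three share one core, an acid-bearing chloroaryl ether with an alkyne, and differ only in the aromatic group on the triple-bonded carbon. In an assay on CHO cells for displacement of a labelled ligand from prostaglandin D2 receptor 2 (Homo sapiens), read by scintillation counting (on this read-out higher numbers stand for weaker inhibition and lower numbers for stronger inhibition), compound 2 stands between the others: compound 1 sits well above it, with a 4.2-fold lower number from compound 1 to compound 2 (0.62 log units; beyond the scatter), whereas compound 3 lies close enough that the two numbers cannot be told apart. Compound 4 `Cn1ccnc1C#Cc1cc(Cl)ccc1OCC(=O)O` has not been measured; it differs from compound 2 in one place: 1-methyl-1H-imidazol-2-yl in place of 2-methylpyridin-3-yl on a triple-bonded carbon.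

Within the data shown here, only one measured step bears on this change, the replacement of pyridin-4-yl by 2-methylpyridin-3-yl, which lowered the number from compound 1 to compound 2 by a modest but clear margin. Among the measured compounds shown here, that step shows that the aromatic group on the alkyne can shift the read-out, but it gives no guide for a five-membered ring with two hetero atoms, and no other pair in the set tests such a ring. The expectation is therefore cautious: in this assay no step beyond the scatter is expected, a 1.4-fold higher number from compound 2 to compound 4 (0.15 log units; within the scatter), with a wide range. Compound 4 is estimated at 200 nM, between 60 nM and 700 nM.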

Compound 4, inhibition constant: 1470 nM
Beside the measured number, compound 4's estimate is 7.4-fold (0.87 log units) below it; the whole stated range lies below it.
By their numbers in this assay, from the lowest: compounds 3 and 2 (each within the scatter of the next); then compound 1; then compound 4.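

In this assay, putting 1-methyl-1H-imidazol-2-yl on the triple-bonded carbon produces the largest step among these compounds (a 10-fold higher number from compound 2 to compound 4 (1.01 log units; beyond the scatter)), and its direction is opposite to that of the earlier change from pyridin-4-yl to 2-methylpyridin-3-yl. The new group also compares unfavourably with pyridin-4-yl (a 2.4-fold higher number from compound 1 to compound 4 (0.39 log units; beyond the scatter)), so the loss is not confined to the comparison with the better of the two pyridines and shows that this position separates aromatic groups more sharply than the first pair alone suggested. No measurement is available that accounts for why the five-membered aromatic ring with 2 hetero atoms gives these higher numbers.

The compounds shown leave open whether the change in the read-out follows the ring size, the number of ring nitrogens or the methyl group, since all three differ together between compound 2 and compound 4. A 1-methyl-1H-pyrazol-5-yl group, a thiazol-2-yl group or a 1H-imidazol-2-yl group without the methyl on the same triple-bonded carbon would help separate these possibilities.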